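Piperidin-1-yl in place of benzyl(ethyl)amino on the core

The compounds below may be only part of what the source reports. "The series", "measured", "known", "first", "only" and "open" are said of these compounds alone.

Compound 1 `CCN(Cc1ccccc1)c1cc(C)nc(N(CC)c2ccc(C(C)C)cc2Br)n1` gives 17 nM in an assay on isolated protein for binding affinity to corticotropin-releasing factor receptor 1 (Homo sapiens) (on this read-out lower numbers stand for stronger inhibition and higher numbers for weaker inhibition), the lowest of the two numbers at hand. Compound 2 `CCN(c1nc(C)cc(C)n1)c1ccc(N(C)C)cc1C` gives 54 nM in this assay, a gap beyond the usual scatter. Compound 3 `CCN(c1nc(C)cc(N2CCCCC2)n1)c1ccc(C(C)C)cc1Br` is not yet measured; it differs from compound 1 by piperidin-1-yl in place of benzyl(ethyl)amino on an aromatic carbon. Among the compounds with values here, no measured pair shows this change, so its direction is open. The step is expected to be modest, within or just beyond the scatter, a 1.8-fold higher number from compound 1 to compound 3 (0.25 log units; within the scatter). For compound 3 the estimate in this assay is 30 nM, with a range from 8 nM to 120 nM.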

Compound 3, inhibition constant: 29 nM
Compound 3: the middle estimate sits 1.0-fold (0.01 log units) above what was measured; the measured number falls inside the stated range.
By their numbers in this assay, from the lowest: compounds 1, 3 and 2 (each within the scatter of the next, the first and the last beyond it).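

In this assay piperidin-1-yl in place of benzyl(ethyl)amino on an aromatic carbon of the shared core gives a 1.7-fold higher number from compound 1 to compound 3 (0.23 log units; within the scatter) and so leaves the number within the usual scatter. This place on the core therefore keeps a comparable number when the six-membered aromatic ring of carbon only leaves and a non-aromatic ring enters. Still open, going by these compounds, is how morpholin-4-yl, piperazin-1-yl or dipropylamino would read at this place, and whether a primary amine or a carboxylic acid would keep the number there. Nothing at hand gives a reason for this result.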